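A few compounds are considered here, and "the series" means these few. Any claim that something is new, unique, unknown or untested is made for them only; others in the source may bear on it.

Measured in an ADME assay (liver) for metabolic stability, with Liver microsome (Homo sapiens) as the target, read by LC-MS, using microsomes, with a stated time of 1 h, tested at 5 uM; on this read-out lower numbers stand for a less stable compound and higher numbers for a more stable compound:
compound 1, `Cc1nc(-c2ccccc2F)c(C(=O)N2CCN(c3cc(Cl)cc(Cl)c3)CC2)o1`, gives 82.3%;
compound 2, `Cc1nc(-c2ccccc2)c(C(=O)N2CCN(c3cc(Cl)cc(Cl)c3)CC2)o1`, gives 66.3%;
compound 3, `COc1cc(OC)cc(N2CCN(C(=O)c3oc(C)nc3-c3cccc(F)c3)CC2)c1`, gives 11.3%.

Compound 1 and compound 2 share one core, and the change hydrogen in place of fluoro on an aromatic carbon gave a number 16 percentage points lower from compound 1 to compound 2 (beyond the scatter) in this assay. Compound 3 is built on a different core, and the difference between the two cores is not broken down here. Compound 4, `COc1cc(OC)cc(N2CCN(C(=O)c3oc(C)nc3-c3ccccc3)CC2)c1`, is not yet measured; it differs from compound 3 by hydrogen in place of fluoro on an aromatic carbon. Within the data shown here, this is the same kind of change as the one from compound 1 to compound 2, but the place differs: there the hydrogen enters ortho to a large group, here meta to a large group. Because compound 3 already stands at 11.3%, little room remains below it, so a smaller step is expected, a number 4.3 percentage points lower from compound 3 to compound 4 (within the scatter), beside the earlier one. Compound 4 is therefore expected to give 7%, between 2% and 18%.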

Compound 4, percent of the compound remaining: 15.8%
The estimate for compound 4 lay 8.8 percentage points below the measured number, within the range that was stated.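

In this assay, hydrogen in place of fluoro gave a number 4.5 percentage points higher from compound 3 to compound 4 (within the scatter), and this change does not carry over unchanged from one core to the other: the same change on two cores in this assay, a number 16 percentage points lower (beyond the scatter) from compound 1 to compound 2 and a number 4.5 percentage points higher (within the scatter) from compound 3 to compound 4, 20.5 percentage points apart, beyond the scatter of two such steps. The two cores differ in one place, and 3,5-dimethoxyphenyl in place of 3,5-dichlorophenyl gave a number 50.5 percentage points lower from compound 2 to compound 4 (beyond the scatter). The fluoro also sits at a different place on the ring in each pair, and these compounds do not show whether that place or the other aryl group accounts for the gap.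

Still open, on these data alone, is what a 3-fluorophenyl would do on the core of compound 1. As far as these compounds go, it is also open where the number would fall with a nitrile or trifluoromethyl group in place of the two methoxy groups.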